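The source may hold more compounds than are shown below. What is called first, only, known or untested is meant among the compounds shown, and "the series" means these compounds.

Two measured compounds frame this step. Compound 1 `CC(C)(O)[C@@H](Nc1nc(Cl)nc2c1ncn2[C@H]1[C@H](O)[C@H](O)[C@]2(CO)C[C@H]12)C1CC1` was run in an ADME assay on Vero 76 cells (Chlorocebus sabaeus) for cytotoxicity, read by microscopy; on this read-out lower numbers stand for higher toxicity in this test and higher numbers for lower toxicity in this test. In this assay compound 1 gives > 100000 nM, which is a limit of the assay rather than a measured number (the limit of > 100000 nM in this assay, at which 1 of the 2 values shown sits). Compound 2 `NCCNC(=O)[C@@]12C[C@@H]1[C@@H](n1cnc3c(NC(C4CC4)C4CC4)nc(Cl)nc31)[C@H](O)[C@@H]2O` is the other measured entry. In this assay compound 2 gives > 50000 nM, again a limit and not a number (the limit of > 50000 nM in this assay, at which 1 of the 2 values shown sits). Within the data shown here, both measured values are thus limits, so where compound 1 stands is known only as a limit, and no step between measured compounds can be drawn from the pair.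

Compound 3 `CC(C)(C)[C@H](Nc1nc(Cl)nc2c1ncn2[C@H]1[C@H](O)[C@H](O)[C@]2(CO)C[C@H]12)C1CC1` has not yet been measured. It differs from compound 1 in a single place: 1-cyclopropyl-2,2-dimethylpropyl in place of 1-cyclopropyl-2-hydroxy-2-methylpropyl on a nitrogen on an aromatic ring. Among the measured compounds shown here, no measured step is at hand to set the size of such a change in this assay. With both measured compounds sitting at limits, the step from compound 1 to compound 3 is expected to be none beyond the scatter, a number no higher from compound 1 to compound 3 (the limit leaves the size open). Compound 3 is accordingly estimated at 100000 nM, within a range from 30000 nM to 300000 nM, and the assay is expected most likely to report only a limit again.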

Compound 3, half-maximal cytotoxic concentration: > 100000 nM
Compound 3 gave a limit, no number; the forecaster's own chance of this, stated with the estimate: 75%; the middle value lies on the limit itself.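

In this assay compound 3 gives > 100000 nM, which is a limit and not a number. Compound 1 stands at the same limit, so no step can be read between compound 1 and compound 3: the limit of > 100000 nM in this assay, at which 2 of the 3 values shown sit.

The compounds shown leave open what actual number either compound would give in this assay, and whether replacing 1-cyclopropyl-2-hydroxy-2-methylpropyl with 1-cyclopropyl-2,2-dimethylpropyl changes the read-out at all.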